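Pyrimidin-4-yl in place of pyridin-3-yl on the ether arm

A few compounds are considered here, and "the series" means these few. Any claim that something is new, unique, unknown or untested is made for them only; others in the source may bear on it.

Measured so far:
compound 1 `O=C(COCc1ccccc1)N1CCN(c2ccc(Cl)cc2Cl)CC1`: 1000 nM
compound 2 `O=C(COCc1ccccn1)N1CCN(c2ccc(Cl)cc2Cl)CC1`: 310 nM
compound 3 `O=C(COCc1cccnc1)N1CCN(c2ccc(Cl)cc2Cl)CC1`: 1090 nM

All three numbers come from a functional assay on HEK293 cells for positive allosteric modulation of metabotropic glutamate receptor 5 (Homo sapiens), read by FLIPR and calcium flux; on this read-out higher numbers stand for an effect only at larger amounts of compound and lower numbers for an effect already at smaller amounts. For the measured compounds named here, compound 3 stands at the highest number of the three, but the step of a 1.1-fold higher number from compound 1 to compound 3 (0.04 log units; within the scatter) is within the scatter, so compound 3 and compound 1 cannot be ordered; only the step of a 3.5-fold higher number from compound 2 to compound 3 (0.55 log units; beyond the scatter) separates compound 3 from a measured neighbour, and that is the one clear gap in this set.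

Compound 4 `O=C(COCc1ccncn1)N1CCN(c2ccc(Cl)cc2Cl)CC1` differs from compound 3 by one change: pyrimidin-4-yl in place of pyridin-3-yl on a saturated chain carbon bound to an oxygen on a saturated carbon. Going by the values given here, two measured steps bear on it. The step of a 3.2-fold lower number from compound 1 to compound 2 (0.51 log units; beyond the scatter) shows that one nitrogen in the six-membered ring can move the number down by a modest amount, and the step of a 3.5-fold higher number from compound 2 to compound 3 (0.55 log units; beyond the scatter) shows that this depends on where in the ring the nitrogen sits. Among the compounds with values here, no measured pair turns a ring with one hetero atom into one with two hetero atoms, so the added nitrogen of compound 4 has no direct precedent here.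

On that basis a modest downward step in this assay, a 2.2-fold lower number from compound 3 to compound 4 (0.34 log units; beyond the scatter), is expected for compound 4, with little confidence in its size. The estimate for compound 4 is 500 nM, with a range from 150 nM to 1600 nM.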

Compound 4, half-maximal effective concentration: 2800 nM
Compound 4: middle estimate off by 5.6-fold (0.75 log units), on the low side; measured number outside the range, above it.
By their numbers in this assay, from the lowest: compound 2; then compounds 1 and 3 (each within the scatter of the next); then compound 4.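

In this assay a six-membered aromatic ring with 2 hetero atoms on a saturated chain carbon bound to an oxygen on a saturated carbon raises the number, with a 2.6-fold higher number from compound 3 to compound 4 (0.41 log units; beyond the scatter) as the result of the added ring nitrogen. Pyrimidin-4-yl also stands clear of the other two rings, with a 2.8-fold higher number from compound 1 to compound 4 (0.45 log units; beyond the scatter) and a 9.0-fold higher number from compound 2 to compound 4 (0.96 log units; beyond the scatter), the second being the widest gap in this set and showing that nitrogen-containing rings at this place do not share one direction relative to phenyl: pyridin-2-yl lies lower, pyridin-3-yl stays within the scatter of it, and pyrimidin-4-yl lies higher. Nothing available explains this reversal.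

With only one ring carrying 2 hetero atoms shown, the effect of the number of ring nitrogens cannot be separated from that of their placement, so the loss seen with pyrimidin-4-yl may or may not extend to pyrimidin-2-yl, pyrimidin-5-yl or pyrazin-2-yl. Also open, going by these compounds, is how a pyridin-2-yl ring carrying a small substituent such as methyl, fluoro or methoxy would read at this place, given that pyridin-2-yl holds the lowest number so far.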